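Chloro in Place of Hydrogen: An Expected Step from Compound 1

The source may report more compounds than this note shows. Statements on the series, on what has been measured and on what is new or still open speak of the compounds shown alone.

Compound 1 `COc1ccc(CNc2cc(OC)c(OC)c(OC)c2)cc1` is the weaker of the two inhibitors that give a number in a functional assay on HCT-116 cells (Homo sapiens) for inhibition, read by MTT assay, with a stated time of 48 h; a higher number here means a weaker inhibitor, a lower number a stronger inhibitor; there compound 1 gives 18400 nM. Compound 3 `C/C=C/C(=O)N(Cc1ccc(OC)cc1)c1cc(OC)c(OC)c(OC)c1` gives 500 nM, and the step of a 37-fold lower number from compound 1 to compound 3 (1.57 log units; beyond the scatter) is large. Compound 2 `COc1cc(NCc2ccccc2)cc(OC)c1OC` stops at the limit of > 80000 nM. The step of an at least 4.3-fold higher number from compound 1 to compound 2 (0.63 log units; beyond the scatter) weakens inhibition. That value of compound 2 is the limit of the assay (the limit of > 80000 nM in this assay, at which 1 of the 3 values shown sits). Compound 4 `COc1ccc(CNc2cc(OC)c(OC)c(OC)c2)cc1Cl` differs from compound 1 by chloro in place of hydrogen on an aromatic carbon. Among the measured compounds shown here, neither measured step exchanges a hydrogen for a chloro, so no step bears directly on this change, and no movement beyond the scatter is expected. Compound 4 is therefore expected to give 12000 nM, between 4000 nM and 40000 nM, which would be an estimated step of a 1.5-fold lower number from compound 1 to compound 4 (0.19 log units; within the scatter).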

Compound 4, half-maximal inhibitory concentration: 41700 nM
Beside the measured number, compound 4's estimate is 3.5-fold (0.54 log units) below it; measured number outside the range, above it.
By their numbers in this assay, from the lowest: compound 3; then compound 1; then compound 4. At a limit, above all of these: compound 2.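

In this assay, the position ortho to a methoxy group proves not to be neutral: chloro in place of hydrogen there gives a 2.3-fold higher number from compound 1 to compound 4 (0.36 log units; beyond the scatter), a modest weakening of inhibition. Among the compounds shown here, the earlier steps changed only a methoxy group and the nitrogen, so this is the first evidence on a ring carbon that carries hydrogen in compound 1. Nothing shown here accounts for this step.

The compounds shown leave open whether fluoro, methyl or hydroxyl at this position would also weaken inhibition. They also leave open whether chloro would have the same effect on compound 3.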